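The compounds below may be only part of what the source reports. "The series", "measured", "known", "first", "only" and "open" are said of these compounds alone.

Measured compounds:
- compound 1, `ClCc1cccc(Cn2cnc3ncnc(Cl)c32)c1`, gives 8120 nM
- compound 2, `ClCc1cccc(Cn2cnc3c(Cl)ncnc32)c1`, gives 33100 nM
- compound 3, `ClCc1ccc(Cn2cnc3nc(Cl)nc(Cl)c32)cc1`, gives 18200 nM

These three compounds were tested in a functional assay on SK-OV-3 cells (Homo sapiens) for cytotoxicity, read by sulforhodamine B assay, with a stated time of 48 h; a lower number here means that less compound is tolerated, a higher number that more compound is tolerated. Compound 3 stands second highest of the three numbers. Its nearest neighbour is compound 2, whose number is within the scatter of that of compound 3, so no order between the two can be claimed. Compound 1 sits further away, with a number beyond the scatter below that of compound 3.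

Compound 4, `ClCc1ccc(Cn2cnc3ncnc(Cl)c32)cc1`, has not yet been measured. Compared with compound 3, the change is hydrogen in place of chloro on an aromatic carbon. Among the compounds with values here, no pair of measured compounds differs by this single change, so the size of the step is not known from the data. Within the data shown here, since compound 1 and compound 2 carry only one chloro group on the fused core and their numbers bracket that of compound 3, the loss of one chloro group in compound 4 is expected to move the number little, perhaps somewhat downward, and likely not beyond the scatter.

For compound 4 in this assay the estimated value is 12000 nM, with a range from 4000 nM to 36000 nM, which corresponds to an expected step of a 1.5-fold lower number from compound 3 to compound 4 (0.18 log units; within the scatter).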

Compound 4, concentration lethal to 50% of the cells: 47900 nM
Estimate against measurement, compound 4: 4.0-fold (0.60 log units) below; the measured number lies above the stated range.
By their numbers in this assay, from the lowest: compound 1; then compounds 3, 2 and 4 (each within the scatter of the next, the first and the last beyond it).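

In this assay, within the data shown here, hydrogen in place of chloro on the aromatic carbon between two ring nitrogen atoms gives a 2.6-fold higher number from compound 3 to compound 4 (0.42 log units; beyond the scatter), the first step in this set that isolates a single position, and the number rises as the chloro group leaves. The earlier compounds shown here could not show this, as none of them formed a pair differing in one place; the result shows that this chloro group is not a silent passenger, since its presence goes with less compound being tolerated, though the step is modest and rests on one pair. What lies behind the step cannot be said, as nothing measured here speaks to its cause.

The compounds shown leave open whether the step is particular to chloro, since an amine or a methoxy group on this same carbon could give a number close to that of compound 3, close to that of compound 4, or far from both. They also leave open whether the same replacement gives a step of similar size when the chloromethyl group stands elsewhere on the benzyl ring, as it does in compound 1.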